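Thioamide to dithiolethione swap across two amide-linked cores

The source may report more compounds than this note shows. Statements on the series, on what has been measured and on what is new or still open speak of the compounds shown alone.

Compound 1 `COc1cc(CNC(=O)CCCC/C=C/C(C)C)ccc1OCCCCOc1ccc(C(N)=S)cc1` gives 49800 nM in a functional assay on MCF7 cells (Homo sapiens) for antiproliferative activity, read by MTT assay, with a stated time of 48 h; a lower number here means a stronger inhibitor, a higher number a weaker inhibitor. Compound 2 `COc1cc(CNC(=O)CCCC/C=C/C(C)C)ccc1OCCCCOc1ccc(-c2cc(=S)ss2)cc1` carries a group of 6 heavy atoms (3 carbon, 3 sulfur; one five-membered aromatic ring with 2 hetero atoms) in place of a group of 3 heavy atoms (1 carbon, 1 nitrogen, 1 sulfur; no ring), on an aromatic carbon and gives 36400 nM in this assay; that change made a 1.4-fold lower number from compound 1 to compound 2 (0.14 log units; within the scatter). Compound 3 `COc1cc(CNC(=O)CCCCCCC(C)C)ccc1OCCCCCOc1ccc(C(N)=S)cc1` gives 49300 nM in this assay; the numbers of compound 1 and compound 3 sit within the scatter of each other, and the difference between the two cores is not broken down here. Compound 4 `COc1cc(CNC(=O)CCCCCCC(C)C)ccc1OCCCCCOc1ccc(-c2cc(=S)ss2)cc1` has not yet been measured. It differs from compound 3 by a group of 6 heavy atoms (3 carbon, 3 sulfur; one five-membered aromatic ring with 2 hetero atoms) in place of a group of 3 heavy atoms (1 carbon, 1 nitrogen, 1 sulfur; no ring), on an aromatic carbon, the same change as that between compound 1 and compound 2, at a place described in the same words. Within the data shown here, the only measured instance of this change gave a 1.4-fold lower number from compound 1 to compound 2 (0.14 log units; within the scatter), a step within the scatter, so no more than a small shift is anticipated here. Among the measured compounds shown here, the step expected in this assay is a 1.4-fold lower number from compound 3 to compound 4 (0.14 log units; within the scatter), resting on the one measured instance, a 1.4-fold lower number from compound 1 to compound 2 (0.14 log units; within the scatter). Compound 4 is therefore estimated at 36000 nM in this assay, with an expected range from 20000 nM to 65000 nM.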

Compound 4, half-maximal inhibitory concentration: 48700 nM
Estimate against measurement, compound 4: 1.4-fold (0.13 log units) below; the measured number falls inside the stated range.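

In this assay, putting the group of 6 heavy atoms with its five-membered aromatic ring in place of the group of 3 heavy atoms gives a 1.0-fold lower number from compound 3 to compound 4 (0.01 log units; within the scatter), so on this second core the change again stays inside the scatter. The two instances agree with each other: the same change on two cores in this assay, a 1.4-fold lower number (0.14 log units; within the scatter) from compound 1 to compound 2 and a 1.0-fold lower number (0.01 log units; within the scatter) from compound 3 to compound 4, 1.4-fold (0.13 log units) apart, within the scatter of two such steps. Among these compounds, this shows that the lack of a clear shift carries over between these two cores, but it rests on only two pairs and does not show that the change has any real effect on antiproliferative activity, or that the same would hold on any other core.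

Open, on these data alone, is what a carboxylic acid, an amine or a nitrile would give at the same place on the six-membered aromatic ring, in place of either group seen here. Also open, as far as these compounds go, is whether the same exchange stays as flat on a core with a much shorter or much longer chain on the amide carbonyl than those of compound 1 and compound 3.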